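From dimethylamino to piperidin-1-yl on a shared core

The source may report more compounds than this note shows. Statements on the series, on what has been measured and on what is new or still open speak of the compounds shown alone.

In an ADME assay on L6 cells (Rattus norvegicus) for cytotoxicity, read by resazurin assay, with a stated time of 72 h (a higher number here means a weaker inhibitor, a lower number a stronger inhibitor), compound 2 (`CN1CCN(CCC(=O)NC2CC3(N(C)C)CC(c4ccccc4)C2C(c2ccccc2)C3)CC1`) gives 95000 nM and compound 3 (`CN1CCN(CCC(=O)N2CCC3(N4CCCCC4)CC(c4ccccc4)C2C(c2ccccc2)C3)CC1`) gives 120000 nM as two values within the scatter of each other. Against compound 2, compound 1 (`CCN(CC)CC(=O)OC1CC2(N3CCCCC3)CC(c3ccccc3)C1C(c1ccccc1)C2`) gives a clearly lower number at 23900 nM beyond the scatter.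

Compound 4 (`CN1CCN(CCC(=O)NC2CC3(N4CCCCC4)CC(c4ccccc4)C2C(c2ccccc2)C3)CC1`) has not yet been measured. Relative to compound 2 it has piperidin-1-yl in place of dimethylamino on a saturated ring carbon while the rest of the structure stays the same.

Among the compounds with values here, no two measured compounds differ in one place only, so no direct step guides the expectation in this assay here. Compound 1 carries piperidin-1-yl and gives 23900 nM while compound 3 also carries it and gives 120000 nM so the group alone does not settle the number. The expected change (a 1.6-fold lower number from compound 2 to compound 4 (0.20 log units; within the scatter)) is small, toward a lower number and within the scatter. For compound 4 the estimated value is 60000 nM with an expected range from 25000 nM to 120000 nM in this test.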

Compound 4, half-maximal inhibitory concentration: 61100 nM
For compound 4 the middle estimate is 1.0-fold (0.01 log units) below the measured one; the measured number falls inside the stated range.
By their numbers in this assay, from the lowest: compound 1; then compounds 4, 2 and 3 (each within the scatter of the next).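

In this assay, putting piperidin-1-yl in place of dimethylamino on the saturated ring carbon gives a 1.6-fold lower number from compound 2 to compound 4 (0.19 log units; within the scatter) and so leaves the reading at this position essentially unchanged, even though the entering group is larger and carries a ring. With piperidin-1-yl held fixed, replacing (((diethylamino)methyl)carbonyl)oxy with ((2-(4-methylpiperazin-1-yl)ethyl)carbonyl)amino gives a 2.6-fold higher number from compound 1 to compound 4 (0.41 log units; beyond the scatter) and shows that this side chain moves the number more than the swap of amines does. No supporting measurement is available to explain either step.

The second step changes the linking atom and the side chain together, so the compounds shown cannot separate their contributions. Going by these compounds, whether a smaller ring amine such as pyrrolidin-1-yl, or morpholin-4-yl with its added ring oxygen, would also leave the number unchanged remains open.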